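Swapping a Pyrimidine for a Pyridine on Two Related Cores

This account rests on a few compounds, and the source may have more. Where it says the series, first, only, none or still open, it means among the compounds named here.

Compound 1 `Cc1nccc(N2CCc3nc(C4(C(=O)Nc5ccc(F)cc5)CCC4)ccc32)n1` gives 21 nM in an assay on HeLa cells for inhibition of Indoleamine 2,3-dioxygenase 1 (Homo sapiens); on this read-out lower numbers stand for stronger inhibition and higher numbers for weaker inhibition. Compound 3 `O=C(Nc1ccc(F)cc1)C1(c2ccc3c(n2)CCN3c2ccccn2)CCC1` differs from it by pyridin-2-yl in place of 2-methylpyrimidin-4-yl on a nitrogen on an aromatic ring in a ring, and in this assay compound 3 gives 10.9 nM, so this change made a step of a 1.9-fold lower number from compound 1 to compound 3 (0.28 log units; within the scatter). Compound 2 `Cc1nccc(N2CCc3cc(C4(C(=O)Nc5ccc(F)cc5)CCC4)ccc32)n1` has a different core; how the two cores differ is not broken down here. In this assay compound 2 gives 5.2 nM, the lowest number of the three measured compounds. Compound 4 `O=C(Nc1ccc(F)cc1)C1(c2ccc3c(c2)CCN3c2ccccn2)CCC1` carries the same change on the core of compound 2: pyridin-2-yl in place of 2-methylpyrimidin-4-yl on a nitrogen on an aromatic ring in a ring. For compound 4 the expected step is a 1.5-fold lower number from compound 2 to compound 4 (0.17 log units; within the scatter), which rests on the earlier outcome of this same change, a 1.9-fold lower number from compound 1 to compound 3 (0.28 log units; within the scatter). Compound 4 is therefore estimated to give 3.5 nM in this assay, with a range from 1.5 nM to 9 nM.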

Compound 4, half-maximal inhibitory concentration: 3.1 nM
The estimate for compound 4 lay 1.1-fold (0.05 log units) above the measured number, within the range that was stated.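

On the core of compound 2, pyridin-2-yl in place of 2-methylpyrimidin-4-yl gives a 1.7-fold lower number from compound 2 to compound 4 (0.22 log units; within the scatter) in this assay. Set beside the earlier step, the change reads alike on both cores: the same change on two cores in this assay, a 1.9-fold lower number (0.28 log units; within the scatter) from compound 1 to compound 3 and a 1.7-fold lower number (0.22 log units; within the scatter) from compound 2 to compound 4, 1.1-fold (0.06 log units) apart, within the scatter of two such steps. This shows that the swap carries from one of these two cores to the other with no visible difference, but each step lies within the scatter, so neither shows a real gain from the swap, and two cores cannot speak for others in the series.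

On these data alone, whether a plain phenyl ring on that nitrogen, or a pyridine carrying an amine, would also read alike on both cores stays open. So does how either core responds to changes elsewhere, such as on the cyclobutane ring.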